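Moving the Chlorine on the Phenyl Ring of Compound 3

The compounds below may be only part of what the source reports. "The series", "measured", "known", "first", "only" and "open" are said of these compounds alone.

Of the compounds shown here, three sharing one core have been tested in a functional assay on HeLa cells (Homo sapiens) for cytotoxicity, read by MTT assay, with a stated time of 48 h, tested at 100 uM; a higher number here means a stronger effect of the compound at the concentration tested, a lower number a weaker effect. Compound 1 `CSc1ccc(/C=N/n2c(Cc3ccc(S(C)(=O)=O)cc3)n[nH]c2=S)cc1` gives 71.9% in this assay, compound 2 `CS(=O)(=O)c1ccc(Cc2n[nH]c(=S)n2/N=C/c2cccnc2)cc1` gives 45.1%, and compound 3 `CS(=O)(=O)c1ccc(Cc2n[nH]c(=S)n2/N=C/c2ccccc2Cl)cc1` gives 76.5%. Compound 3 holds the highest of the three numbers, but the step of a number 4.6 percentage points higher from compound 1 to compound 3 (within the scatter) lies within the scatter, so those two cannot be told apart; only the gap to compound 2 is clear, as a number 31.4 percentage points higher from compound 2 to compound 3 (beyond the scatter) shows, and the same applies to a number 26.8 percentage points lower from compound 1 to compound 2 (beyond the scatter).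

Compound 4 `CS(=O)(=O)c1ccc(Cc2n[nH]c(=S)n2/N=C/c2ccc(Cl)cc2)cc1` has not yet been measured. It differs from compound 3 in one place: 4-chlorophenyl in place of 2-chlorophenyl on a carbon with a double bond to nitrogen. Among the measured compounds shown here, no measured step swaps a chlorine between two positions of the same ring, so the guide is indirect. The closest hint is compound 1, whose 4-(methylsulfanyl)phenyl ring sits on the same carbon and whose number lies within the scatter of compound 3. Only the swap to pyridin-3-yl in compound 2 moved the number beyond the scatter. The expected step is therefore small, a number 4.5 percentage points lower from compound 3 to compound 4 (within the scatter), with no clear direction. Compound 4 is estimated at 72%, with a range from 55% to 88%.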

Compound 4, a percentage reported as activity, at one concentration (the size of the read-out at that concentration, not a potency): 57%
Estimate against measurement, compound 4: 15 percentage points above, within the range that was stated.
By their numbers in this assay, from the lowest: compound 2; then compound 4; then compounds 1 and 3 (each within the scatter of the next).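

Among the compounds shown here, with the same atoms on the same carbon, moving the chlorine alone shifts the number in this assay clearly (a number 19.5 percentage points lower from compound 3 to compound 4 (beyond the scatter)), so the place of the chlorine on this ring matters, something no earlier step could show. Until now, only the pyridin-3-yl ring had stood clearly apart from the other two rings, but compound 4 now stands apart from compound 1, with chloro in place of methylsulfanyl (a number 14.9 percentage points lower from compound 1 to compound 4 (beyond the scatter)). It also stands apart from the pyridin-3-yl compound (a number 11.9 percentage points higher from compound 2 to compound 4 (beyond the scatter)), which places 4-chlorophenyl clearly between the pyridin-3-yl ring on one side and the 2-chlorophenyl and 4-(methylsulfanyl)phenyl rings on the other.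

The compounds shown leave open whether a fluorine, a methyl or a methoxy group would show the same difference between the two places on the phenyl ring, and each number remains a read-out at one concentration rather than a potency. Nothing available here explains why moving the chlorine changes the number.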